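The source may hold more compounds than are shown below. What is called first, only, known or untested is meant among the compounds shown, and "the series" means these compounds.

Three compounds have numbers in an ADME assay on microsomes from liver (Mus musculus) for metabolic stability, read by LC-MS, using NADPH, with a stated time of 10 min, tested at 10 uM; a lower number here means that the compound disappears faster, a higher number that the compound lasts longer. There compound 1 `N#Cc1ccnc(Oc2nn(C3CCC3)c3ncnc(N)c23)c1` gives 0.4 h, and compound 3 `Nc1ncnc2c1c(Oc1cc(O)ccn1)nn2C1CCC(F)(F)CC1` gives 1.13 h. Compound 2 `Nc1ncnc2c1c(Oc1cc(C(F)(F)F)ccn1)nn2C1CC1` gives > 2.41 h, which is a limit of the assay and not a number. Compound 2 therefore stands at the limit of > 2.41 h in this assay, at which 1 of the 3 values shown sits.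

Compound 4 `Nc1ncnc2c1c(Oc1cc(C(F)(F)F)ccn1)nn2C1CCC(O)C1` departs from compound 2 in one place: 3-hydroxycyclopentyl in place of cyclopropyl on an aromatic nitrogen. Put simply, 3-hydroxycyclopentyl sits in place of cyclopropyl on an aromatic nitrogen.

For the measured compounds named here, no two measured compounds differ in one place only, so no measured step shows what such a swap does. The best guide is compound 3, which also differs from compound 2 in the group on that nitrogen, and compound 3 gives 1.13 h. In this assay a shorter half-life is therefore expected, by more than the usual scatter. The expected step of an at least 2.4-fold lower number from compound 2 to compound 4 (0.38 log units; beyond the scatter) is a fall of moderate size, though its true size is uncertain. For compound 4 the estimated half-life is 1 h, with an expected range from 0.35 h to 2.6 h.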

Compound 4, half-life: 0.3 h
Beside the measured number, compound 4's estimate is 3.3-fold (0.52 log units) above it, and the stated range ends above it.
By their numbers in this assay, from the lowest: compounds 4 and 1 (each within the scatter of the next); then compound 3. At a limit, above all of these: compound 2.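

For the compounds shown here, replacing cyclopropyl with 3-hydroxycyclopentyl on the aromatic nitrogen gives an at least 8.0-fold lower number from compound 2 to compound 4 (0.90 log units; beyond the scatter) in this assay, and this is the first step here that rests on a change in one place only. It shows that the group on this nitrogen can alone shift the half-life beyond the scatter, which compounds 1 and 3 could not show, as each differs from compound 2 in more than one place. Compound 2 stands at a limit of the assay and not at a number, so only the smallest possible size of this fall is known: the limit of > 2.41 h in this assay, at which 1 of the 4 values shown sits.

Going by these compounds, whether the larger ring or its hydroxy group carries the fall stays open, and a plain cyclopentyl or a methoxycyclopentyl on the same nitrogen would help to separate the two. Also open, on these data alone, is how an open chain such as n-butyl or a ring bearing an amine would behave there.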